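Ortho substitution on the aryl amine of a coumarin ester series

A few compounds are considered here, and "the series" means these few. Any claim that something is new, unique, unknown or untested is made for them only; others in the source may bear on it.

Measured compounds in a functional assay on the whole organism (strain Wistar albino) for inhibition, with Rattus norvegicus as the target, read by paw edema, with stated times of 30 min and 3 h, at a dose of 20 mg/kg by the oral route; on this read-out lower numbers stand for less inhibition and higher numbers for more inhibition at the one dose given (going by the name of the read-out):
compound 1 `COc1ccc(NCC(=O)Oc2ccc3c(C)cc(=O)oc3c2)cc1`: 37.2%
compound 2 `COc1ccccc1NCC(=O)Oc1ccc2c(C)cc(=O)oc2c1`: 26.6%
compound 3 `Cc1cc(=O)oc2cc(OC(=O)CNc3nc4ccccc4s3)ccc12`: 40.4%

Compound 2 gives the lowest number of the three in this assay; compound 1 lies nearer to it and compound 3 furthest, both higher and both beyond the scatter. Going by the values given here, the one step that changes a single place, a number 10.6 percentage points lower from compound 1 to compound 2 (beyond the scatter), moved the methoxy group from one position of the aryl ring to the other and lowered the read-out modestly.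

Compound 4 `Cc1cc(=O)oc2cc(OC(=O)CNc3ccccc3Cl)ccc12` is not yet measured. It differs from compound 2 by chloro in place of methoxy on an aromatic carbon, and the same difference read one bond further out is 2-methoxyphenyl to 2-chlorophenyl. Among the compounds with values here, no measured step exchanges methoxy for chloro, so the only bearing is indirect: the ring position is kept, and only a small group on it is swapped. For compound 4 the expected step from compound 2 is therefore a number 3.4 percentage points higher from compound 2 to compound 4 (within the scatter), within the scatter, leaving the estimate for compound 4 at 30% with a range of 18% to 42%.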

Compound 4, a percentage reported as inhibition, in the whole organism at one dose (the size of the read-out at that dose, not a potency): 12.8%
The estimate for compound 4 lay 17.2 percentage points above the measured number; the whole stated range lies above it.
By their numbers in this assay, from the lowest: compound 4; then compound 2; then compounds 1 and 3 (each within the scatter of the next).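

In this assay, the read-out at this aromatic carbon depends on which group sits there, not only on where a methoxy stands, with a number 13.8 percentage points lower from compound 2 to compound 4 (beyond the scatter) in the exchange of methoxy for chloro. Against the other methoxy placement, the change to 2-chlorophenyl gives a number 24.4 percentage points lower from compound 1 to compound 4 (beyond the scatter) and is the largest step seen so far in the series. No data at hand give a reason for either step.

Open, going by these compounds, is whether an amine or a carboxylic acid on this same carbon would keep the number low. Also open, on these data alone, is how chloro would read at the place held by methoxy in compound 1.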